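The compounds below may be only part of what the source reports. "The series", "measured", "known", "first", "only" and "open" are said of these compounds alone.

Measured compounds in an assay on isolated protein for inhibition of Amine oxidase [flavin-containing] B (Homo sapiens), read by fluorescence, with stated times of 30 min and 1 h; a lower number here means a stronger inhibitor, a higher number a weaker inhibitor:
- compound 1, `COc1ccc2c(c1)cc(C(=O)NCc1ccccc1)n2C`; compound 1 gives > 100000 nM, a limit of the assay.
- compound 2, `CCOC(=O)c1cc2cc(OCCCC3CCN(Cc4ccccc4)CC3)ccc2n1C`; compound 2 gives > 100000 nM, a limit of the assay.
- compound 3, `Cn1c(C(=O)O)cc2cc(OCCCC3CCN(Cc4ccccc4)CC3)ccc21`; compound 3 gives > 100000 nM, a limit of the assay.

Within the data shown here, compound 3 stands where every compound so far stands: at a limit, with no number. Among the measured compounds shown here, the single step between measured compounds that differ in one place, a step that the two limits leave unreadable from compound 2 to compound 3 (hydrogen in place of ethyl on an oxygen next to a carbonyl group), cannot be read because of the limit of > 100000 nM in this assay, at which 3 of the 3 values shown sit. Compound 1 differs from compound 3 in more than one place, so its value shows only that it, too, returns no number.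

Compound 4 is `Cn1c(C(=O)Nc2ccccc2)cc2cc(OCCCC3CCN(Cc4ccccc4)CC3)ccc21`. It differs from compound 3 by anilino in place of hydroxy on a carbonyl carbon. For the measured compounds named here, no measured step bears on this change: the one step to the acid is unreadable, and the amide compound 1 is not a one-place neighbour. With all three values at the limit there is no direction to take from the data; the expectation is therefore that compound 4 most likely also sits at the limit, with the expected step that the limit leaves unreadable from compound 3 to compound 4 not readable beyond scatter. The estimate for compound 4 is 150000 nM, with a range from 30000 nM to 1000000 nM.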

Compound 4, half-maximal inhibitory concentration: > 100000 nM
Compound 4: a limit, no number (the forecaster's own chance of this, stated with the estimate: 80%); the middle value is on the limit's open side.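

No step to compound 4 from compound 2 or from compound 3 can be read, because both ends of each step are limits, not numbers: the limit of > 100000 nM in this assay, at which 4 of the 4 values shown sit.

The compounds shown leave open whether any change to this series gives a number in this assay, and how anilino, hydroxy and ethoxy on the carbonyl carbon compare.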